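From Ester to Acid at the Amide Side Chain

The source may hold more compounds than are shown below. What is called first, only, known or untested is meant among the compounds shown, and "the series" means these compounds.

- compound 1 `CCn1c(C(=O)NCCC(=O)OC)ccc1C(CC)(CC)c1ccc(C#CC(O)(CC)CC)c(C)c1` gives > 50000 nM (a limit of the assay, not a number)
- compound 2 `CCn1c(C(=O)NCC(=O)O)ccc1C(CC)(CC)c1ccc(C#CC(O)(CC)CC)c(C)c1` gives 5140 nM
- compound 3 `CCn1cc(C(CC)(CC)c2ccc(C#CC(O)(CC)CC)c(C)c2)cc1C(=O)NCC(=O)OC` gives 26500 nM

All three values come from a functional assay on MCF7 cells (Homo sapiens) for antiproliferative activity, read by MTT assay, with a stated time of 72 h; a higher number here means a weaker inhibitor, a lower number a stronger inhibitor. Compound 3 at 26500 nM holds the higher of the two true numbers, and the gap to compound 2 at 5140 nM lies beyond the scatter.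

Compound 4 `CCn1cc(C(CC)(CC)c2ccc(C#CC(O)(CC)CC)c(C)c2)cc1C(=O)NCCC(=O)O` has the same atoms as compound 3, joined differently: carboxymethyl in place of methoxycarbonyl on a saturated chain carbon bound to an amide-type nitrogen. Carboxymethyl stands in place of methoxycarbonyl on a saturated chain carbon bound to an amide-type nitrogen, which also reads as (methoxycarbonyl)methyl to 2-carboxyethyl.

Within the data shown here, one measured step bears on this change. In an at least 9.7-fold lower number from compound 1 to compound 2 (0.98 log units; beyond the scatter), a methyl ester likewise gives way to a free acid, although the chain there shortens rather than lengthens and the core differs. On that single step, a lower number is expected in this assay. The expected step is a 4.4-fold lower number from compound 3 to compound 4 (0.65 log units; beyond the scatter). Compound 4 is estimated at 6000 nM, with an expected range of 2000 nM to 18000 nM.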

Compound 4, half-maximal inhibitory concentration: 30600 nM
Compound 4: middle estimate off by 5.1-fold (0.71 log units), on the low side; the measured number lies above the stated range.
By their numbers in this assay, from the lowest: compound 2; then compounds 3 and 4 (each within the scatter of the next). At a limit, above all of these: compound 1.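

In this assay, the exchange of (methoxycarbonyl)methyl for 2-carboxyethyl at this place, on a saturated chain carbon bound to an amide-type nitrogen, gives a 1.2-fold higher number from compound 3 to compound 4 (0.06 log units; within the scatter), so here a free acid and a methyl ester cannot be told apart. The earlier exchange of an ester for an acid gave an at least 9.7-fold lower number from compound 1 to compound 2 (0.98 log units; beyond the scatter), so a gain on moving to the acid is not general among the compounds shown, and compound 4 goes against it. The size of that earlier step remains only a bound because compound 1 stands at a limit of the assay: the limit of > 50000 nM in this assay, at which 1 of the 4 values shown sits.

The compounds shown do not separate the part played by chain length from that of the core. Going by these compounds, how a primary amide or a longer chain ending in a carboxylic acid would read at this place also stays open.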